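The source may hold more compounds than are shown below. What is called first, only, known or untested is meant among the compounds shown, and "the series" means these compounds.

Compound 1 `CC(=O)Nc1ccc2[nH]c(C)nc2c1` gives 1260000 nM in an ADME assay on microsomes from liver for inhibition of cytochrome P450 2B1 (Rattus norvegicus); on this read-out higher numbers stand for weaker inhibition and lower numbers for stronger inhibition.
Compound 2 `CCCCC(=O)Nc1ccc2[nH]c(C)nc2c1` gives 417000 nM in this assay.
Compound 3 `Clc1cc(Cl)c2[nH]cnc2c1` gives 53700 nM in this assay.

Among these three, compound 1 stands highest in this assay. Its nearest neighbour is compound 2, reached by the step of a 3.0-fold lower number from compound 1 to compound 2 (0.48 log units; beyond the scatter); compound 3, which differs from compound 1 in several places at once, lies further away and is the lowest number of the set, so only what its two values show can be said of that pair.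

The step from compound 1 to compound 4 `CCOc1ccc2[nH]c(C)nc2c1` is a different kind of change: ethoxy in place of acetamido on an aromatic carbon. Among the measured compounds shown here, the single measured step, from compound 1 to compound 2, alters the saturated chain on the carbonyl carbon and leaves the aromatic carbon untouched, so it bears on the new step only indirectly, as a sign that changes near the amide move the number by modest amounts. For the measured compounds named here, no measured pair varies the group on that aromatic carbon itself. The expectation is therefore a small movement in this assay, leaning toward a lower number, of about a 2.1-fold lower number from compound 1 to compound 4 (0.32 log units; beyond the scatter). Compound 4 is estimated at 600000 nM, with a range from 200000 nM to 2000000 nM.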

Compound 4, half-maximal inhibitory concentration in the cytochrome P450 2B1 assay: 56200 nM
Estimate against measurement, compound 4: 11-fold (1.03 log units) above, outside the stated range (below it).
By their numbers in the cytochrome P450 2B1 assay, from the lowest: compounds 3 and 4 (each within the scatter of the next); then compound 2; then compound 1.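

Ethoxy in place of acetamido shows that the group on this aromatic carbon matters far more in the cytochrome P450 2B1 assay than the saturated chain on the carbonyl carbon: the new change gives a 22-fold lower number from compound 1 to compound 4 (1.35 log units; beyond the scatter), whereas the earlier chain change gave only a 3.0-fold lower number from compound 1 to compound 2 (0.48 log units; beyond the scatter). The larger step comes with the loss of the carbonyl and the amide hydrogen, so the amide itself is not needed for inhibition of this enzyme in compound 4. In a physicochemical assay for lipophilicity (a higher number here means a more lipophilic compound, a lower number a more polar compound), compound 1 gives 0.61 and compound 4 gives 1.93. In the physicochemical assay the same change gives a number 1.32 log units higher from compound 1 to compound 4 (beyond the scatter), so the stronger inhibition may go with higher lipophilicity, although this single pair cannot separate that link from the removal of the amide: the measured partition coefficient of compound 1, 0.61, and of compound 4, 1.93, a number 1.32 log units higher (beyond the scatter)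

The compounds shown leave open whether lipophilicity or the loss of the amide matters more, and a more polar group without the amide hydrogen on this aromatic carbon, such as an amine or a carboxylic acid, would help to separate the two. They also leave open whether a longer alkoxy chain in place of ethoxy would move the number further, or whether the effect of ethoxy already marks the end of the trend.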